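Swapping furan for thiophene on a dihydropyrimidinone thioester

A few compounds are considered here, and "the series" means these few. Any claim that something is new, unique, unknown or untested is made for them only; others in the source may bear on it.

Measured compounds:
compound 1, `COC(=O)C1=C(C)NC(=O)NC1c1cccs1`: 19%
compound 2, `CC1=C(C(=O)SC(C)C)C(c2ccco2)NC(=O)N1`: 22%

In an assay on membranes from HEK293 cells for displacement of a labelled ligand from adenosine receptor A2b (Homo sapiens), read by scintillation counting, with a stated time of 30 min, tested at 1 uM (a higher number here means more inhibition at the concentration tested (going by the name of the read-out), a lower number less inhibition), compound 2 gives the higher of the two numbers, but compound 1 lies within the scatter of it, so the two read as equal. Compound 3, `CC1=C(C(=O)SC(C)C)C(c2cccs2)NC(=O)N1`, follows from compound 2 by one change: thiophen-2-yl in place of furan-2-yl on a saturated ring carbon. Since compound 1 already carries thiophen-2-yl and sits level with compound 2, no step beyond the scatter is expected in this assay. The expected step of a number 1 percentage points higher from compound 2 to compound 3 (within the scatter) is small, and compound 3 is estimated at 23%, with a range from 10% to 38%.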

Compound 3, a percentage reported as inhibition, at one concentration (the size of the read-out at that concentration, not a potency): 1%
Beside the measured number, compound 3's estimate is 22 percentage points above it; the measured number lies below the stated range.
By their numbers in this assay, from the lowest: compound 3; then compounds 1 and 2 (each within the scatter of the next).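

In this assay, thiophen-2-yl in place of furan-2-yl on the saturated ring carbon gives a number 21 percentage points lower from compound 2 to compound 3 (beyond the scatter) when the isopropylsulfanyl group stays on the carbonyl, so this position separates the two rings. With thiophen-2-yl held fixed, isopropylsulfanyl in place of methoxy on the carbonyl carbon gives a number 18 percentage points lower from compound 1 to compound 3 (beyond the scatter), so the change at the carbonyl also registers. Nothing measured here accounts for either step. The compounds shown leave open how furan-2-yl behaves with methoxy on the carbonyl, and how a phenyl ring on the saturated ring carbon would read.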